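This account rests on a few compounds, and the source may have more. Where it says the series, first, only, none or still open, it means among the compounds named here.

Compounds measured so far:
- compound 1 `COc1cc(NC(C)CCCNC(=O)Nc2cccc(Cl)c2)c2ncccc2c1` gives 37000 nM
- compound 2 `COc1cc(NC(C)CCCNC(=O)Nc2ccc(C(F)(F)F)cc2)c2ncccc2c1` gives 24000 nM

Both values come from a functional assay on NCI-H460 cells (Homo sapiens) for inhibition, read by MTT assay, with a stated time of 72 h; a higher number here means a weaker inhibitor, a lower number a stronger inhibitor. Going by the values given here, the only measured step, a 1.5-fold lower number from compound 1 to compound 2 (0.19 log units; within the scatter), lies within the scatter, so compound 2 holds no distinct place in this small set. That step put 4-(trifluoromethyl)phenyl in place of 3-chlorophenyl.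

Compound 3 `COc1cc(NC(C)CCCNC(=O)Nc2ccc(Cl)cc2)c2ncccc2c1` has not yet been measured. It differs from compound 2 by chloro in place of trifluoromethyl on an aromatic carbon, with chloro in place of trifluoromethyl on an aromatic carbon, para to a large group. The same difference reads 4-(trifluoromethyl)phenyl to 4-chlorophenyl. Among the compounds with values here, the one related change, a 1.5-fold lower number from compound 1 to compound 2 (0.19 log units; within the scatter), stayed within the scatter, so no step beyond the scatter is expected here.

The expected step is a 1.2-fold higher number from compound 2 to compound 3 (0.07 log units; within the scatter). For compound 3 the estimated value is 28000 nM, with an expected range from 13000 nM to 60000 nM.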

Compound 3, half-maximal inhibitory concentration: 34000 nM
Beside the measured number, compound 3's estimate is 1.2-fold (0.08 log units) below it; the measured number falls inside the stated range.
By their numbers in this assay, from the lowest: compounds 2, 3 and 1 (each within the scatter of the next).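

With chloro in place of trifluoromethyl on an aromatic carbon, para to a large group, a 1.4-fold higher number from compound 2 to compound 3 (0.15 log units; within the scatter) in this assay shows that this exchange at this position stays within the scatter. The second comparison, a 1.1-fold lower number from compound 1 to compound 3 (0.04 log units; within the scatter) for 4-chlorophenyl in place of 3-chlorophenyl, adds that moving the chloro also stays within the scatter, whereas the earlier step had changed both the group and its place at once. Nothing available here accounts for how close these numbers lie.

The compounds shown leave open whether any other group on this aromatic ring, such as an amine or a carboxylic acid, would give a step beyond the scatter. They also leave open what a longer chain in place of the present one would do to the number in this assay and whether changes away from this ring matter more.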